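This account rests on a few compounds, and the source may have more. Where it says the series, first, only, none or still open, it means among the compounds named here.

Working notes on the series.

Compound 1 `COc1ccc(NC2=CC(=O)c3c(nc4n3[C@H]3OC[C@@H](O)[C@H]3OC4)C2=O)cc1` sits at a limit of a functional assay on HeLa cells (Homo sapiens) for inhibition, read by sulforhodamine B assay (on this read-out lower numbers stand for stronger inhibition and higher numbers for weaker inhibition), not at a number: in this assay compound 1 gives > 8000 nM. Compound 2 `O=C1C=C(N2CCCCC2)C(=O)c2c1nc1n2[C@H]2OC[C@@H](O)[C@H]2OC1` is likewise reported only as a limit in this assay, where compound 2 gives > 16000 nM. Within the data shown here, both values shown are therefore limits, the one the limit of > 8000 nM in this assay, at which 1 of the 2 values shown sits, and the other (the limit of > 16000 nM in this assay, at which 1 of the 2 values shown sits), and no measured step between two numbers exists in the set; compound 1 stands among values that are all limits, with nothing to rank it against.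

Compound 3 `O=C1C(NCc2ccccc2)=CC(=O)c2c1nc1n2[C@H]2OC[C@@H](O)[C@H]2OC1` differs from compound 1 by a single change, (benzyl in place of 4-methoxyphenyl on an amine nitrogen), a benzyl in place of 4-methoxyphenyl on the amine nitrogen. Among the measured compounds shown here, with both known values standing at limits, there is no measured step to lean on, so the expected step from compound 1 to compound 3 in this assay is a step that the limit leaves unreadable from compound 1 to compound 3, not beyond the scatter in either direction. Compound 3 is therefore estimated to give 12000 nM in this assay, with a range from 3000 nM to 50000 nM, most likely again returned as a limit.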

Compound 3, half-maximal inhibitory concentration: 11000 nM
Compound 3: middle estimate off by 1.1-fold (0.04 log units), on the high side; the range from low to high includes it.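

No step from compound 1 to compound 3 can be read in this assay, because the value of compound 1 is only a limit: the limit of > 8000 nM in this assay, at which 1 of the 3 values shown sits.

The compounds shown leave open whether benzyl in place of 4-methoxyphenyl on the amine nitrogen changes inhibition at all, and how compound 3 ranks against compound 1.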